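Replacing a Carbamate Arm with Phenyl on the Amide Carbonyl

A few compounds are considered here, and "the series" means these few. Any claim that something is new, unique, unknown or untested is made for them only; others in the source may bear on it.

Of the compounds shown here, three that share a phenyltelluropropyl amide chain have been measured in a functional assay on PC-3 cells (Homo sapiens) for inhibition, with a stated time of 48 h; on this read-out higher numbers stand for weaker inhibition of growth and lower numbers for stronger inhibition of growth. Compound 1, `COc1ccc(N(CC(=O)NCCC[Te]c2ccccc2)C(=O)CNC(=O)OC(C)(C)C)cc1`, gives 1700 nM in this assay. Compound 2, `COc1ccc(N(CC(=O)NCCC[Te]c2ccccc2)C(=O)CCSC2=C(C)C(=O)c3ccccc3C2=O)cc1`, gives 2750 nM, and compound 3, `CC1=C(SCCC(=O)OCC(=O)NCCC[Te]c2ccccc2)C(=O)c2ccccc2C1=O`, gives 2400 nM; both of these numbers lie within the usual scatter of the number for compound 1, so the three stand together rather than apart.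

The unmeasured compound 4, `COc1ccc(N(CC(=O)NCCC[Te]c2ccccc2)C(=O)c2ccccc2)cc1`, departs from compound 1 by a single change: phenyl in place of ((tert-butoxycarbonyl)amino)methyl on a carbonyl carbon. Going by the values given here, no pair of measured compounds shows this change, so its effect is not known from the data. Given that compound 1 with 1700 nM sits among three compounds whose numbers all fall within the scatter of one another, compound 4 is expected to show a step of a 1.1-fold lower number from compound 1 to compound 4 (0.05 log units; within the scatter), in either direction but not beyond the scatter. Compound 4 is therefore estimated at 1500 nM in this assay, with a range from 500 nM to 4500 nM.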

Compound 4, concentration for 50% growth inhibition: 2690 nM
Beside the measured number, compound 4's estimate is 1.8-fold (0.25 log units) below it, and the stated range covers the measured number.
By their numbers in this assay, from the lowest: compounds 1, 3, 4 and 2 (each within the scatter of the next).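

Going by these compounds alone, at the carbonyl carbon whose other neighbour is the amide-type nitrogen, the first direct pair in this assay gives a 1.6-fold higher number from compound 1 to compound 4 (0.20 log units; within the scatter), a step that stays within the scatter. The open-chain ((tert-butoxycarbonyl)amino)methyl group, which carries hydrogen-bond donor and acceptor atoms, can therefore be exchanged for phenyl, which carries neither and brings an aromatic ring, with no readable change in this growth read-out. Nothing measured here offers an explanation for this result.

The compounds shown leave open whether an aminomethyl group, a carboxylic acid or a longer alkyl chain on this carbonyl carbon would also stay within the scatter. They also leave open whether a phenyl ring bearing a methoxy group or a halogen would do so.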